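Cytotoxicity of para-substituted analogues on bovine kidney cells

The compounds below may be only part of what the source reports. "The series", "measured", "known", "first", "only" and "open" are said of these compounds alone.

Measured in an ADME assay on MDBK cells (Bos taurus) for cytotoxicity, read by MTT assay, with a stated time of 96 h; a higher number here means that more compound is tolerated, a lower number that less compound is tolerated:
compound 1 `Cn1c(-c2ccc([N+](=O)[O-])cc2)nc2cc(C(F)(F)F)ccc21`: > 100000 nM, a limit of the assay rather than a number
compound 2 `CC(=O)Nc1ccc(-c2nc3cc(C(F)(F)F)ccc3n2C)cc1`: 46000 nM
compound 3 `Cn1c(-c2ccc(N)cc2)nc2cc(C(F)(F)F)ccc21`: 74000 nM

Compound 1 stands at the limit of > 100000 nM in this assay, at which 1 of the 3 values shown sits. Among the two numbers, compound 3 has the higher one, and its nearest neighbour is compound 2, from which it differs by a 1.6-fold higher number from compound 2 to compound 3 (0.21 log units; within the scatter). From compound 1, the steps read an at least 2.1-fold lower number from compound 1 to compound 2 (0.33 log units; beyond the scatter) and an at least 1.3-fold lower number from compound 1 to compound 3 (0.13 log units; that floor lies within the scatter).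

Compound 4 `CCC(=O)Nc1ccc(-c2nc3cc(C(F)(F)F)ccc3n2C)cc1` carries the change (propanoyl in place of hydrogen on a nitrogen on an aromatic ring). The step that bears on it is the reverse of the acetyl-to-hydrogen step, a 1.6-fold higher number from compound 2 to compound 3 (0.21 log units; within the scatter), which stayed within the scatter. A step of the same kind, and therefore no change beyond the scatter, is expected for compound 4 in this assay, a 1.5-fold lower number from compound 3 to compound 4 (0.19 log units; within the scatter). The estimate for compound 4 is 48000 nM, between 22000 nM and 100000 nM.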

Compound 4, half-maximal cytotoxic concentration: > 100000 nM
Compound 4 ended at the assay's limit; the forecaster's own chance of this, stated with the estimate: 10%; middle value at least 2.0-fold (0.31 log units) from the limit.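

In this assay, among the compounds shown here, methyl in place of hydrogen on the saturated chain carbon bound to the carbonyl carbon gives an at least 2.1-fold higher number from compound 2 to compound 4 (0.33 log units; beyond the scatter), the first step beyond the scatter among changes on this nitrogen. Propanoyl in place of hydrogen gives an at least 1.3-fold higher number from compound 3 to compound 4 (0.13 log units; that floor lies within the scatter), and that floor alone does not separate the two compounds. Compound 1 and compound 4 both stand at a limit, and the step between them cannot be read: the limit of > 100000 nM in this assay, at which 2 of the 4 values shown sit.

As far as these compounds go, how far compound 4 lies past its limit stays open. So does whether a butanoyl group or a longer chain on this nitrogen also reaches the limit.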